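Compound 3 and its methoxy analogue, compound 4

The source may report more compounds than this note shows. Statements on the series, on what has been measured and on what is new or still open speak of the compounds shown alone.

Compound 1 `N#Cc1cnc(NCc2cnccc2C(F)(F)F)cc1N[C@H]1C[C@@H](O)C1`: 90%
Compound 2 `N#Cc1cnc(NCc2cnccc2C(F)(F)F)cc1N[C@H]1CC[C@@H](O)CC1`: 33%
Compound 3 `N#Cc1cnc(NCc2cnccc2C(F)(F)F)cc1NC[C@H]1CC[C@@H](O)CC1`: 41%

an ADME assay on S9 fraction from liver (Homo sapiens) for metabolic stability, with a stated time of 1 h (a lower number here means that less of the compound is left, a higher number that more of the compound is left), shows a number 49 percentage points lower from compound 1 to compound 3 (beyond the scatter), and similarly a number 57 percentage points lower from compound 1 to compound 2 (beyond the scatter). The remaining comparison, a number 8 percentage points higher from compound 2 to compound 3 (within the scatter), leaves compound 3 level with compound 2, and only compound 1 stands clearly apart.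

Compound 4 `CO[C@H]1CC[C@@H](CNc2cc(NCc3cnccc3C(F)(F)F)ncc2C#N)CC1` differs from compound 3 in one place: methyl in place of hydrogen on an oxygen on a saturated carbon, hydroxy to methoxy. Among the measured compounds shown here, none of the measured steps alters this hydroxy group. All three exchange the ring or add a chain carbon, so their sizes say little here. The expectation therefore starts from compound 3 at 41%, with no step beyond the scatter anticipated and only a slight, uncertain lean downward. The expected step is a number 6 percentage points lower from compound 3 to compound 4 (within the scatter). For compound 4 the estimated value is 35%, within an expected range of 15% to 55%.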

Compound 4, percent of the compound remaining: 4%
Beside the measured number, compound 4's estimate is 31 percentage points above it, outside the stated range (below it).
By their numbers in this assay, from the lowest: compound 4; then compounds 2 and 3 (each within the scatter of the next); then compound 1.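

In this assay, the hydroxy group on the cyclohexyl ring proves not to be a neutral place: methyl in place of its hydrogen gives a number 37 percentage points lower from compound 3 to compound 4 (beyond the scatter). The methoxy compound also separates from the other two, with a number 29 percentage points lower from compound 2 to compound 4 (beyond the scatter) and a number 86 percentage points lower from compound 1 to compound 4 (beyond the scatter), so a change of a single carbon on this oxygen carries a step beyond the scatter. Nothing available explains this loss. As far as these compounds go, whether an ethoxy group or an amine at this place would behave like the methoxy group stays open. So does the effect of the same methyl on the 3-hydroxycyclobutyl group of compound 1.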